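The compounds below may be only part of what the source reports. "The series", "measured", "known", "first", "only" and "open" are said of these compounds alone.

Three compounds sharing one core have numbers in a functional assay (aorta) with Rattus norvegicus as the target; a higher number here means that more compound is needed for the effect, a lower number that less compound is needed. Compound 1 (`COc1ccc(-c2nc(CNC(=O)c3cccnc3)sc2-c2ccc(OC)cc2)cc1`) gives 8.2 uM, compound 2 (`COc1ccc(-c2nc(CNC(=O)NC(C)C)sc2-c2ccc(OC)cc2)cc1`) gives 5.7 uM, and compound 3 (`COc1ccc(-c2nc(C(=O)N(C)C)sc2-c2ccc(OC)cc2)cc1`) gives 3 uM. Compound 3 thus lies within the scatter of compound 2 and lower than compound 1. The data show a 2.7-fold lower number from compound 1 to compound 3 (0.44 log units; beyond the scatter), a modest gap, while a 1.9-fold lower number from compound 2 to compound 3 (0.28 log units; within the scatter) and a 1.4-fold lower number from compound 1 to compound 2 (0.16 log units; within the scatter) are not separated from the scatter.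

The next compound, compound 4 (`COc1ccc(-c2nc(C(=O)N=C(N)N)sc2-c2ccc(OC)cc2)cc1`), keeps the core and the carbonyl of compound 3 but changes what the carbonyl carries: a group of 4 heavy atoms (1 carbon, 3 nitrogen; no ring) in place of a group of 3 heavy atoms (2 carbon, 1 nitrogen; no ring), on a carbonyl carbon. Going by the values given here, no measured step makes this exchange, and no tested compound carries the entering group. Among the compounds with values here, the nearest evidence is the one other change on a carbonyl carbon, a 1.4-fold lower number from compound 1 to compound 2 (0.16 log units; within the scatter), which stayed within the scatter. Even the replacement of a whole side chain gave only a 2.7-fold lower number from compound 1 to compound 3 (0.44 log units; beyond the scatter). On these small steps, no shift beyond the scatter is expected in this assay, though the novelty of the group calls for a wide range. The expected change is a 1.3-fold higher number from compound 3 to compound 4 (0.12 log units; within the scatter). The estimate for compound 4 is 4 uM, with an expected range from 1.3 uM to 12 uM.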

Compound 4, concentration for half-maximal effect: > 100 uM
Compound 4: a limit, no number; the forecaster's own chance of this, stated with the estimate: 5%; at least 25-fold (1.39 log units) between middle value and limit.
By their numbers in this assay, from the lowest: compounds 3, 2 and 1 (each within the scatter of the next, the first and the last beyond it). At a limit, above all of these: compound 4.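

The value of compound 4 is a limit and not a number: the limit of > 100 uM in this assay, at which 1 of the 4 values shown sits. The carbonyl carbon proves far from indifferent in this assay: replacing dimethylamino there with the entering group gives an at least 33-fold higher number from compound 3 to compound 4 (1.52 log units; beyond the scatter), and the two compounds with longer side chains on the aromatic carbon stand apart from compound 4 as well, with an at least 17-fold higher number from compound 2 to compound 4 (1.24 log units; beyond the scatter) and an at least 12-fold higher number from compound 1 to compound 4 (1.08 log units; beyond the scatter). Going by these compounds alone, the exchange itself is small in count, 4 heavy atoms for 3, yet it moves the number further than the replacement of a whole side chain did in a 2.7-fold lower number from compound 1 to compound 3 (0.44 log units; beyond the scatter), so the earlier steps gave no measure of how much this place can change the result.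

The compounds shown leave open how far the true value of compound 4 lies past its limit, and so the full size of these steps. They also leave open which part of the entering group goes with the change, since a plain amino group, a methylamino group or a hydroxyl on the same carbonyl carbon would each test a smaller piece of it.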